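Swapping the Acyl Group on a Trimethoxyphenyl Amide

This account rests on a few compounds, and the source may have more. Where it says the series, first, only, none or still open, it means among the compounds named here.

Of the compounds shown here, two that share a trimethoxyphenyl core have been tested in a functional assay on MGC-803 cells (Homo sapiens) for inhibition, read by MTT assay, with a stated time of 48 h; on this read-out higher numbers stand for weaker inhibition and lower numbers for stronger inhibition. Compound 1 `COc1ccc(CNc2cc(OC)c(OC)c(OC)c2)cc1[N+](=O)[O-]` gives 19400 nM, while compound 2 `C=C(C)C(=O)N(Cc1ccc(OC)c(O)c1)c1cc(OC)c(OC)c(OC)c1` gives 390 nM, the lowest number of the pair and a gap well beyond the usual scatter. Compound 3 `COc1ccc(CN(C(=O)CCCl)c2cc(OC)c(OC)c(OC)c2)cc1O` is not yet measured; its difference from compound 2 is 2-chloroethyl in place of 1-methylethenyl on a carbonyl carbon, the 1-methylethenyl group leaving and a 2-chloroethyl group entering on the carbonyl carbon. The step of a 2.1-fold higher number from compound 2 to compound 3 (0.31 log units; beyond the scatter) in this assay is expected to be small, toward slightly weaker inhibition. Compound 3 is estimated at 800 nM, within a range of 200 nM to 3000 nM.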

Compound 3, half-maximal inhibitory concentration: 140 nM
Beside the measured number, compound 3's estimate is 5.7-fold (0.76 log units) above it; measured number outside the range, below it.
By their numbers in this assay, from the lowest: compound 3; then compound 2; then compound 1.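

Exchanging 1-methylethenyl for 2-chloroethyl on the carbonyl carbon in this assay gives a 2.8-fold lower number from compound 2 to compound 3 (0.44 log units; beyond the scatter) with stronger inhibition. The double bond of 1-methylethenyl is therefore not required for inhibition in this pair, and a 2-chloroethyl group with the same number of heavy atoms serves better. Nothing shown here gives a measured reason for this step.
The compounds shown leave open whether the gain comes from the chlorine or from losing the double bond. A plain propyl chain, or an amine in place of the chlorine, would help separate those two possibilities.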